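Permeability notes on compound 2 and the untested compound 3

The source may report more compounds than this note shows. Statements on the series, on what has been measured and on what is new or still open speak of the compounds shown alone.

Measured so far:
compound 1 `CC(C)(C)[C@@H](O)C(=O)N1CSC[C@H]1C(=O)NCc1cc(Cl)ccc1-n1cnnn1`: 19 10^-6 cm/s
compound 2 `O=C(NCc1cc(Cl)ccc1-n1cnnn1)[C@@H]1C[C@@H]2C[C@@H]2N1C(=O)[C@H](O)Cc1ccccn1`: 1.2 10^-6 cm/s

In an ADME assay on Caco-2 cells (Homo sapiens) for permeability, read by LC-MS, in the apical to basolateral direction, with a stated time of 60 min, at pH 6.5 (a higher number here means that the compound crosses the layer faster, a lower number that the compound crosses the layer more slowly), compound 1 gives 19 10^-6 cm/s and compound 2 gives 1.2 10^-6 cm/s. Compound 2 stands lowest of the two numbers, below compound 1 by a margin beyond the scatter. Compound 3 `O=C(NCc1cc(Cl)ccc1-n1cnnn1)[C@@H]1C[C@@H]2C[C@@H]2N1C(=O)[C@H](O)c1ccccc1F` differs from compound 2 by 2-fluorophenyl in place of (pyridin-2-yl)methyl on a saturated chain carbon bound to a carbonyl carbon and an oxygen on a saturated carbon. Within the data shown here, no measured pair carries this same change, so the expectation rests on compound 2 alone. An upward step a 4.2-fold higher number from compound 2 to compound 3 (0.62 log units; beyond the scatter) beyond the scatter is expected in this assay. Compound 3 is expected to give about 5 10^-6 cm/s, in the range 2 10^-6 cm/s to 12 10^-6 cm/s.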

Compound 3, apparent permeability: 16 10^-6 cm/s
Estimate against measurement, compound 3: 3.2-fold (0.51 log units) below, and the stated range ends below it.
By their numbers in this assay, from the lowest: compound 2; then compounds 3 and 1 (each within the scatter of the next).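

In this assay the position on a saturated chain carbon bound to a carbonyl carbon and an oxygen on a saturated carbon proves strongly responsive: 2-fluorophenyl in place of (pyridin-2-yl)methyl gives a 13-fold higher number from compound 2 to compound 3 (1.12 log units; beyond the scatter), a large step. Both groups hold the same count of heavy atoms, so the step does not track group size by that count. No measurement on these compounds bears on the reason for the step.

Going by these compounds, the fluorine, the ring nitrogen and the methylene link all change together, so their separate contributions remain open. A plain phenyl or benzyl group at this place would separate them.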